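Thiosemicarbazide series: chloro to methoxy, cytotoxicity

A few compounds are considered here, and "the series" means these few. Any claim that something is new, unique, unknown or untested is made for them only; others in the source may bear on it.

compound 1 `CCOc1ccc(NC(=S)NNC(=O)c2ccncc2)cc1`: > 300000 nM
compound 2 `O=C(NNC(=S)Nc1cccc(Cl)c1)c1ccncc1`: > 300000 nM

In an ADME assay on MCF-10A cells (Homo sapiens) for cytotoxicity, read by WST assay, with a stated time of 48 h (a lower number here means a stronger inhibitor, a higher number a weaker inhibitor), compound 1 reaches only the limit, > 300000 nM. In this assay compound 2 likewise gives only the limit, > 300000 nM. Both values sit at the same point, (the limit of > 300000 nM in this assay, at which 2 of the 2 values shown sit), so compound 2 stands level with compound 1 and neither yields a number. Compound 3 `COc1cccc(NC(=S)NNC(=O)c2ccncc2)c1` is not yet measured; it differs from compound 2 by methoxy in place of chloro on an aromatic carbon. Among the measured compounds shown here, no step between measured compounds is available here. The expected step of a number no higher from compound 2 to compound 3 (the limit leaves the size open) stays within the scatter, most likely returning a limit rather than a number. For compound 3 the estimate in this assay is 300000 nM, with a range from 100000 nM to 1000000 nM.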

Compound 3, half-maximal inhibitory concentration: > 300000 nM
Compound 3: no number, only a limit; the forecaster's own chance of this, stated with the estimate: 85%; the middle value lies on the limit itself.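

Compound 3 gives only a limit in this assay, > 300000 nM, so no step from compound 2 to compound 3 can be read: the limit of > 300000 nM in this assay, at which 3 of the 3 values shown sit.

The compounds shown leave open whether methoxy in place of chloro on an aromatic carbon alters cytotoxicity at all.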